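The source may report more compounds than this note shows. Statements on the series, on what has been measured and on what is new or still open speak of the compounds shown alone.

In a toxicity assay on PC-12 cells (Rattus norvegicus) for cytotoxicity, read by MTT assay (a higher number here means a weaker inhibitor, a lower number a stronger inhibitor), compound 2 `Cc1cc(C)cc(-n2nc(-c3ccc(C(F)(F)F)cc3O)nc2-c2ccccc2O)c1` gives 263000 nM, and compound 1 `CCc1ccc(-n2nc(-c3ccc(C(F)(F)F)cc3O)nc2-c2ccccc2O)cc1` gives 147000 nM, so the two numbers lie within the scatter of each other. Compound 3 `Oc1cc(C(F)(F)F)ccc1-c1nc(-c2ccccc2O)n(-c2cc(F)cc(F)c2)n1` has 3,5-difluorophenyl in place of 3,5-dimethylphenyl on an aromatic nitrogen. Going by the values given here, only one measured step bears on this change, a swap of the group at that same nitrogen: a 1.8-fold higher number from compound 1 to compound 2 (0.25 log units; within the scatter). That step stayed small, so no shift beyond the scatter is expected in this assay. The estimated step is a 1.3-fold lower number from compound 2 to compound 3 (0.12 log units; within the scatter). For compound 3 the expected value is 200000 nM, with an estimated range from 90000 nM to 450000 nM.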

Compound 3, half-maximal inhibitory concentration: 53700 nM
The estimate for compound 3 lay 3.7-fold (0.57 log units) above the measured number; measured number below the stated range.
By their numbers in this assay, from the lowest: compound 3; then compounds 1 and 2 (each within the scatter of the next).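

In this assay, the group on this aromatic nitrogen moved the number beyond the scatter, which the earlier pair had not shown: 3,5-difluorophenyl in place of 3,5-dimethylphenyl gave a modest step (a 4.9-fold lower number from compound 2 to compound 3 (0.69 log units; beyond the scatter)), and in place of 4-ethylphenyl another (a 2.7-fold lower number from compound 1 to compound 3 (0.44 log units; beyond the scatter)). Both steps run in the same direction, toward the lower number. Nothing measured here accounts for the shift.

On these data alone, what a 3,5-dichlorophenyl or 3,5-dimethoxyphenyl group would give at this nitrogen stays open. So does whether a single fluorine on the phenyl ring would give the same lower number.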